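Acyl to sulfonyl swap on the shared core

The compounds below may be only part of what the source reports. "The series", "measured", "known", "first", "only" and "open" are said of these compounds alone.

Measured so far:
compound 1 `CN1CCN(c2ccc(C3=NN(C(=O)c4ccc(C(F)(F)F)cc4)C(c4ccc(N(C)C)cc4)C3)cc2)CC1`: in a functional assay on HeLa cells (Homo sapiens) for inhibition (on this read-out lower numbers stand for stronger inhibition and higher numbers for weaker inhibition), compound 1 gives > 100000 nM, a limit of the assay
compound 2 `CN1CCN(c2ccc(C3=NN(C(=O)/C=C/c4ccccc4)C(c4ccc(N(C)C)cc4)C3)cc2)CC1`: in this assay compound 2 gives > 10000 nM, also a limit of the assay

Compound 2 thus stands at a limit only, as does compound 1. The step that the two limits leave unreadable from compound 1 to compound 2 cannot be read (the limit of > 10000 nM in this assay, at which 1 of the 2 values shown sits, (the limit of > 100000 nM in this assay, at which 1 of the 2 values shown sits)). Compound 3 `CN1CCN(c2ccc(C3=NN(S(=O)(=O)c4ccc(F)cc4)C(c4ccc(N(C)C)cc4)C3)cc2)CC1` differs from compound 2 by (4-fluorophenyl)sulfonyl in place of (2-phenylethenyl)carbonyl on an amine nitrogen in a ring. Among the measured compounds shown here, no measured step bears on this change, and neither measured compound supplies a number. Compound 3 is therefore expected to remain weak, the step that the limit leaves unreadable from compound 2 to compound 3 being an estimate without support from measured steps. The estimate for compound 3 is 30000 nM, range 5000 nM to 200000 nM, most likely again reported as a limit.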

Compound 3, half-maximal inhibitory concentration: > 10000 nM
Compound 3: no number, only a limit; the forecaster's own chance of this, stated with the estimate: 75%; the middle value is on the limit's open side.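

Among the compounds shown here, no step among compound 1, compound 2 and compound 3 can be read, since each value is a limit of the assay: the limit of > 10000 nM in this assay, at which 2 of the 3 values shown sit.
Going by these compounds, how strongly each compound inhibits in this assay remains open, as does any difference between the carbonyl and sulfonyl compounds.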